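Swapping Chloro for Bromo on Two Related Cores

The source may report more compounds than this note shows. Statements on the series, on what has been measured and on what is new or still open speak of the compounds shown alone.

Measured compounds, with growth inhibition on an ADME assay on 184B5 cells (Homo sapiens) for cytotoxicity, read by sulforhodamine B assay, with a stated time of 48 h; a higher number here means a weaker inhibitor of growth, a lower number a stronger inhibitor of growth:
- compound 1, `O=C1C(=O)N(CN2CCN(c3ccnc4cc(C(F)(F)F)ccc34)CC2)c2cc(Cl)ccc21`: 25300 nM
- compound 2, `O=C1C(=O)N(CN2CCN(c3ccnc4cc(C(F)(F)F)ccc34)CC2)c2cc(Br)ccc21`: 21800 nM
- compound 3, `NC(=S)N/N=C1/C(=O)N(CN2CCN(c3ccnc4cc(C(F)(F)F)ccc34)CC2)c2cccc(Cl)c21`: 87800 nM

Compound 1 and compound 2 share one core and differ only in a single halogen, (bromo in place of chloro on an aromatic carbon). In this assay that change gave a 1.2-fold lower number from compound 1 to compound 2 (0.06 log units; within the scatter), so the two values cannot be told apart.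

Compound 3 is built on a different core; the difference between the two cores is not broken down here. In this assay compound 3 gives 87800 nM, the highest of the three numbers, standing beyond the scatter from both compound 1 and compound 2.

Compound 4, `NC(=S)N/N=C1/C(=O)N(CN2CCN(c3ccnc4cc(C(F)(F)F)ccc34)CC2)c2cccc(Br)c21`, is not yet measured. It relates to compound 3 as compound 2 relates to compound 1: bromo in place of chloro on an aromatic carbon. The surroundings are not identical, since here the group sits ortho to a fused ring and meta to a fused ring, whereas in compound 1 and compound 2 it sits meta to a fused ring and para to a fused ring, so this is the same kind of change rather than the same change.

Going by the values given here, the one measured example of this kind of change, compound 1 to compound 2, moved the number by a 1.2-fold lower number from compound 1 to compound 2 (0.06 log units; within the scatter), within the scatter. On that basis the step from compound 3 to compound 4 in this assay is expected to be small, a 1.2-fold lower number from compound 3 to compound 4 (0.06 log units; within the scatter). Compound 4 is therefore estimated at 76000 nM, with a likely range from 40000 nM to 150000 nM, resting on the value of compound 3 at 87800 nM.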

Compound 4, concentration for 50% growth inhibition: 26400 nM
The estimate for compound 4 lay 2.9-fold (0.46 log units) above the measured number, and the stated range ends above it.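

In this assay, putting bromo in place of chloro on an aromatic carbon gave a 3.3-fold lower number from compound 3 to compound 4 (0.52 log units; beyond the scatter). Set beside the earlier example, the same swap clearly did not have the same size on the two cores, so the result from one pair could not simply be carried over to the other: the same change on two cores in this assay, a 1.2-fold lower number (0.06 log units; within the scatter) from compound 1 to compound 2 and a 3.3-fold lower number (0.52 log units; beyond the scatter) from compound 3 to compound 4, 2.9-fold (0.46 log units) apart, beyond the scatter of two such steps. Going by these compounds alone, this does not show what sets the two pairs apart: the halogen in compound 3 and compound 4 sits ortho to a fused ring and meta to a fused ring, a different place from the one it holds in compound 1 and compound 2, so the change of core and the change of place are tied together, and two pairs are too few to establish a rule for the series.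

The compounds shown leave open whether the gap would remain if chloro and bromo were compared at the same ring place on both cores. They also leave open how fluoro, iodo, methyl or a plain hydrogen on that carbon would compare, and so whether the shift seen with bromo on the core of compound 3 is particular to that halogen.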